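A Smaller Group on the Carbonyl in a Toxicity Test

The source may report more compounds than this note shows. Statements on the series, on what has been measured and on what is new or still open speak of the compounds shown alone.

Compound 1 `COc1ccc(-c2cnc(NC(=O)c3ccc(F)cc3)n2Cc2ccccc2)cc1`: > 100000 nM, a limit
Compound 2 `COc1ccc(-c2nc3ncc(-c4ccc(F)cc4)cc3[nH]2)cc1`: > 100000 nM, a limit
Compound 3 `COc1ccc(-c2cnc(NC(=O)C3CCNCC3)n2C)cc1`: > 100000 nM, a limit

These values come from a toxicity assay on THP-1 cells (Homo sapiens) for inhibition; on this read-out lower numbers stand for higher toxicity in this test and higher numbers for lower toxicity in this test. Compound 3 gives only a limit, > 100000 nM, and no exact number. All three compounds stand together at the limit of > 100000 nM in this assay, at which 3 of the 3 values shown sit.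

Compound 4 `CCC(=O)Nc1ncc(-c2ccc(OC)cc2)n1C` differs from compound 3 in one place: ethyl in place of piperidin-4-yl on a carbonyl carbon. In words, this is ethyl in place of piperidin-4-yl on a carbonyl carbon.

Among the compounds with values here, no measured pair shows a single change of this kind. In this assay, no shift beyond the usual scatter is expected. That expectation rests on compound 3, whose limit is > 100000 nM. The expected change is a number no higher from compound 3 to compound 4 (the limit leaves the size open). For compound 4, the estimated value is 100000 nM, within an expected range of 50000 nM to 200000 nM.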

Compound 4, half-maximal cytotoxic concentration: > 100000 nM
Compound 4: only a limit was reported; the forecaster's own chance of this, stated with the estimate: 90%; the middle value sits exactly at the limit.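

Within the data shown here, compound 3 and compound 4 each give only a limit in this assay, so no step between them can be read. The compounds shown leave open how ethyl and piperidin-4-yl truly compare on the carbonyl carbon, because all of them sit together: the limit of > 100000 nM in this assay, at which 4 of the 4 values shown sit.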